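Swapping the aryl group on a shared core

The compounds below may be only part of what the source reports. "The series", "measured", "known", "first", "only" and "open" are said of these compounds alone.

compound 1, `CCCCCCCCCCCCNc1nc(SCc2ccc(C(F)(F)F)cc2)nc2ccccc12`, 26000 nM
compound 2, `CCCCCCCCCCCCCCNc1nc(SCc2ccc(C(F)(F)F)cc2)nc2ccccc12`, > 50000 nM (a limit of the assay)
compound 3, `COc1ccccc1Nc1nc(SCc2ccc(C(F)(F)F)cc2)nc2ccccc12`, 14100 nM

Three compounds share one core and differ only in the group on the nitrogen on the aromatic ring. In a functional assay on PC-3 cells (Homo sapiens) for cytotoxicity, read by MTT assay, with a stated time of 72 h (on this read-out lower numbers stand for stronger inhibition and higher numbers for weaker inhibition), compound 1 gives 26000 nM. Compound 2 gives only a limit of the assay, > 50000 nM. The step of an at least 1.9-fold higher number from compound 1 to compound 2 (0.28 log units; that floor lies within the scatter) has a floor that lies within the scatter, which follows from the limit of > 50000 nM in this assay, at which 1 of the 3 values shown sits. Compound 3 gives 14100 nM in this assay, a number that sits within the scatter of the number for compound 1.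

Compound 4, `Fc1ccc(Nc2nc(SCc3ccc(C(F)(F)F)cc3)nc3ccccc23)cc1`, has not yet been measured. It differs from compound 3 by 4-fluorophenyl in place of 2-methoxyphenyl on a nitrogen on an aromatic ring. Within the data shown here, no measured step touches this part of the molecule: the only measured step alters the saturated chain, not the group on the ring nitrogen. Among the measured compounds shown here, nothing among the measured compounds points to a step beyond the scatter in this assay in either direction. Compound 4 is therefore expected to give 15000 nM, between 5000 nM and 45000 nM. The step of a 1.1-fold higher number from compound 3 to compound 4 (0.03 log units; within the scatter) is expected to stay within the scatter.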

Compound 4, half-maximal inhibitory concentration: 7070 nM
Beside the measured number, compound 4's estimate is 2.1-fold (0.33 log units) above it, within the range that was stated.
By their numbers in this assay, from the lowest: compounds 4, 3 and 1 (each within the scatter of the next, the first and the last beyond it). At a limit, above all of these: compound 2.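

In this assay, 4-fluorophenyl in place of 2-methoxyphenyl on a nitrogen on an aromatic ring gives a 2.0-fold lower number from compound 3 to compound 4 (0.30 log units; within the scatter). Among these compounds, this is the first measured step between two aryl groups at this position, and it shows that the two numbers stay within the scatter of each other although 2-methoxyphenyl carries a hydrogen-bond acceptor and 4-fluorophenyl carries none. Nothing measured here offers a reason for this step.

The two groups differ both in their substituent and in where it sits on the ring, so the compounds shown cannot separate these two differences. On these data alone, how an unsubstituted phenyl, or a phenyl bearing an amine or a carboxylic acid, would read in this assay remains open.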